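Chain growth on the aryl ether oxygen: compound 4

A few compounds are considered here, and "the series" means these few. Any claim that something is new, unique, unknown or untested is made for them only; others in the source may bear on it.

Compound 1 `COc1cc(O)c(C(C)=O)cc1Br`: 3000000 nM
Compound 2 `CCCCOc1cc(OC)c(Br)cc1C(C)=O`: 56900000 nM
Compound 3 `CCCCCCOc1cc(OC)c(Br)cc1C(C)=O`: 53100000 nM

In a functional assay, with a stated time of 10 min (on this read-out lower numbers stand for stronger inhibition and higher numbers for weaker inhibition), compound 3 holds the second highest of the three numbers; the nearest is that of compound 2, within the scatter, while the furthest is separated from it by the step of an 18-fold higher number from compound 1 to compound 3 (1.25 log units; beyond the scatter). Compound 4 `CCCCCCCCCCCCOc1cc(OC)c(Br)cc1C(C)=O` differs from compound 3 by hexyl in place of hydrogen on a saturated chain carbon, six bonds along the chain from an oxygen on an aromatic ring. The step that bears directly on this is a 1.1-fold lower number from compound 2 to compound 3 (0.03 log units; within the scatter), which lay within the scatter. The large steps of a 19-fold higher number from compound 1 to compound 2 (1.28 log units; beyond the scatter) and an 18-fold higher number from compound 1 to compound 3 (1.25 log units; beyond the scatter) concern the first alkyl group placed on the oxygen, not its further lengthening. A step of no size beyond the scatter is therefore expected in this assay. Compound 4 is expected to give 55000000 nM (range 25000000 nM to 120000000 nM), an expected step of a 1.0-fold higher number from compound 3 to compound 4 (0.02 log units; within the scatter).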

Compound 4, half-maximal inhibitory concentration: 23100000 nM
Estimate against measurement, compound 4: 2.4-fold (0.38 log units) above; measured number below the stated range.
By their numbers in this assay, from the lowest: compound 1; then compound 4; then compounds 3 and 2 (each within the scatter of the next).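

Further lengthening of the chain on the oxygen on an aromatic ring is not without effect in this assay: the series shows a 2.3-fold lower number from compound 3 to compound 4 (0.36 log units; beyond the scatter) and a 2.5-fold lower number from compound 2 to compound 4 (0.39 log units; beyond the scatter), both modest and toward stronger inhibition. The earlier chain lengthening stayed within the scatter, so the change appears only with compound 4, whose number, 23100000 nM, remains higher than that of compound 1 at 3000000 nM. No supporting measurement accounts for this shift. The compounds shown leave open whether a longer chain would extend the step, and how a chain ending in an amine or a carboxylic acid would read.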